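Moving the hydroxyl on the phenyl ring of compound 3

This account rests on a few compounds, and the source may have more. Where it says the series, first, only, none or still open, it means among the compounds named here.

Measured so far in an ADME assay on microsomes from liver (Rattus norvegicus) for metabolic stability, read by LC-MS, with a stated time of 30 min, tested at 0.5 uM; a lower number here means that less of the compound is left, a higher number that more of the compound is left:
- compound 1 `c1ccc(-c2cc(-c3csc(N=C4NCCCN4)n3)cs2)cc1` gives 30%
- compound 2 `c1ccc(-n2ccc(-c3csc(N=C4NCCCN4)n3)n2)cc1` gives 1.6%
- compound 3 `Oc1ccc(-c2nc(-c3csc(N=C4NCCCN4)n3)cs2)cc1` gives 53%

In this assay compound 3 stands highest of the three, and compound 1 and compound 2 both lie beyond the scatter from it. Compound 4 `Oc1ccccc1-c1nc(-c2csc(N=C3NCCCN3)n2)cs1` has the same atoms joined differently, with 2-hydroxyphenyl in place of 4-hydroxyphenyl on an aromatic carbon and the rest unchanged. For the measured compounds named here, no measured pair differs in one place only, so the expectation is loose. Compound 3 (53%) already tops the series, which leaves a modest fall as the likelier outcome. The expected change is a number 13 percentage points lower from compound 3 to compound 4 (beyond the scatter) in this assay and may barely clear the scatter. The estimate for compound 4 is 40% (range 15% to 65%).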

Compound 4, percent of the compound remaining: 38%
Beside the measured number, compound 4's estimate is 2 percentage points above it; the measured number falls inside the stated range.
By their numbers in this assay, from the lowest: compound 2; then compounds 1 and 4 (each within the scatter of the next); then compound 3.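

The study's first comparison that differs in one place only shows that, on this aromatic carbon, the placement of the hydroxyl on the phenyl ring matters by itself. In this assay the swap of 4-hydroxyphenyl for 2-hydroxyphenyl gives a number 15 percentage points lower from compound 3 to compound 4 (beyond the scatter), although both groups have the same atoms and counted features. Nothing measured here accounts for this step. The compounds shown leave open how a methoxy group or an amine in place of the hydroxyl would fare in this assay. They also leave open whether the same shift would appear on another core.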